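The source may hold more compounds than are shown below. What is called first, only, known or untested is meant among the compounds shown, and "the series" means these compounds.

Compound 2, `NC(=S)Nc1cccc(OCCCCc2ccccc2)c1`, is known here only by a limit: in an ADME assay on Ava5 cells (Homo sapiens) for cytotoxicity (a higher number here means that more compound is tolerated, a lower number that less compound is tolerated), compound 2 gives > 50000 nM, which is a limit of the assay rather than a number. Compound 1, `NC(=S)Nc1cccc(OCCCc2ccccc2)c1`, stands the same way; in this assay compound 1 gives > 50000 nM, again a limit. Among the measured compounds shown here, the one measured step, a step that the two limits leave unreadable from compound 1 to compound 2, is therefore not readable in size, since (the limit of > 50000 nM in this assay, at which 2 of the 2 values shown sit). Compound 3, `NC(=S)Nc1cccc(OCCCCCc2ccccc2)c1`, carries the same kind of change one place further; the difference is benzyl in place of phenyl on a saturated chain carbon, four bonds along the chain from an oxygen on an aromatic ring. For the measured compounds named here, the only measured step that bears on it is the unreadable one, so it offers no direction and no size, only that neither end of it reached a measurable value. Compound 3 is accordingly expected to sit at or past the same limit, estimated at 60000 nM with a range from 30000 nM to 150000 nM. The expected step that the limit leaves unreadable from compound 2 to compound 3 is thus none beyond the scatter.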

Compound 3, half-maximal cytotoxic concentration: 22000 nM
Compound 3: the middle estimate sits 2.7-fold (0.44 log units) above what was measured; measured number outside the range, below it.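

At this place, on a saturated chain carbon four bonds along the chain from an oxygen on an aromatic ring, benzyl in place of phenyl gives an at least 2.2-fold lower number from compound 2 to compound 3 (0.35 log units; beyond the scatter) in this assay. Among the compounds shown here, the earlier step of the same kind cannot be read, so this is the first sign that the same change can leave less compound tolerated, and compound 3 is the first here to give a measured number rather than a limit. The start of the new step is itself a limit and not a number, so only a minimum size can be read from it: the limit of > 50000 nM in this assay, at which 2 of the 3 values shown sit.

On these data alone, whether a longer chain would lower the number further remains open, as one readable step gives no trend. As far as these compounds go, it is equally open how an amine or a carboxylic acid in place of the benzyl would read in this assay.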